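The source may hold more compounds than are shown below. What is called first, only, known or untested is meant among the compounds shown, and "the series" means these compounds.

Three compounds share one core and were tested in an assay on isolated protein for activation of cGMP-dependent protein kinase 1 (Homo sapiens), read by ADP-Glo, with stated times of 30 min and 2 h; on this read-out lower numbers stand for an effect already at smaller amounts and higher numbers for an effect only at larger amounts of compound. Compound 1 `O=C(O)C12CC(CN3CCC[C@H](O[C@H](CO)c4cc(Cl)cc(Cl)c4)[C@@H]3c3ccccc3)(C1)C2` gives > 200000 nM, which is a limit of this assay. Compound 2 `OC[C@@H](O[C@H]1CCCN(Cc2ncc[nH]2)[C@H]1c1ccccc1)c1cc(Cl)cc(Cl)c1` likewise gives > 200000 nM, also a limit. Among the compounds with values here, compound 3 `O=C(O)c1ccc(CN2CCC[C@H](O[C@H](CO)c3cc(Cl)cc(Cl)c3)[C@@H]2c2ccccc2)cc1` gives 77000 nM, the only number among the three. The other two values are limits (the limit of > 200000 nM in this assay, at which 2 of the 3 values shown sit). The step that the two limits leave unreadable from compound 1 to compound 2 is unreadable, while the steps of an at least 2.5-fold lower number from compound 1 to compound 3 (0.41 log units; beyond the scatter) and an at least 2.5-fold lower number from compound 2 to compound 3 (0.41 log units; beyond the scatter) both point toward compound 3.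

Compound 4 `CC(=O)NS(=O)(=O)c1ccc(CN2CCC[C@H](O[C@H](CO)c3cc(Cl)cc(Cl)c3)[C@@H]2c2ccccc2)cc1` differs from compound 3 by acetylsulfamoyl in place of carboxy on an aromatic carbon. Within the data shown here, both readable steps concern the group on the saturated chain carbon bound to the ring amine nitrogen, and both were at least modest; none touches the substituent on the aromatic ring that changes here, so no measured step bears directly on this change. Compound 4 is therefore expected to stay close to compound 3, with an estimated step of a 1.1-fold lower number from compound 3 to compound 4 (0.04 log units; within the scatter). The estimated value of compound 4 in this assay is 70000 nM, within a range from 25000 nM to 200000 nM.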

Compound 4, half-maximal effective concentration: > 200000 nM
Compound 4: a limit, no number (the forecaster's own chance of this, stated with the estimate: 30%); middle value at least 2.8-fold (0.45 log units) from the limit.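

In this assay, within the data shown here, this is the first step at the carboxy group on the aromatic carbon, para to a large group, since all earlier steps concerned the group on the saturated chain carbon bound to the ring amine nitrogen. Acetylsulfamoyl in place of carboxy gives an at least 2.5-fold higher number from compound 3 to compound 4 (0.41 log units; beyond the scatter), so this position does not tolerate every replacement, even though both groups carry 1 hydrogen-bond donor and no net charge. Compound 4 gives a limit and not a number, so the full size of the step stays unknown: the limit of > 200000 nM in this assay, at which 3 of the 4 values shown sit.

The compounds shown leave open whether any other group at this place, such as a tetrazole, a primary amide or a carboxylic acid on a longer chain, would keep a measurable value. On these data alone, with a single number among the four compounds, it also remains open how far this value can move.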